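A few compounds are considered here, and "the series" means these few. Any claim that something is new, unique, unknown or untested is made for them only; others in the source may bear on it.

Of the compounds shown here, three built on a shared core have been tested in a functional assay on A549 cells (Homo sapiens) for antiproliferative activity, read by MTT assay, with a stated time of 48 h; on this read-out lower numbers stand for stronger inhibition and higher numbers for weaker inhibition. Compound 1 `Cc1ccc2[nH]c(-c3cn(-c4ccccc4)nc3-c3ccccc3)nc2c1` gives 3610 nM. Compound 2 `FC(F)(F)c1ccc2[nH]c(-c3cn(-c4ccccc4)nc3-c3ccccc3)nc2c1` gives 5930 nM. Compound 3 `COc1ccc(-c2nn(-c3ccccc3)cc2-c2nc3cc(C(F)(F)F)ccc3[nH]2)cc1` gives 4820 nM. The change methyl in place of trifluoromethyl on an aromatic carbon produced the step of a 1.6-fold lower number from compound 2 to compound 1 (0.22 log units; within the scatter). Compound 3 differs from compound 2 by methoxy in place of hydrogen on an aromatic carbon, and that change produced the step of a 1.2-fold lower number from compound 2 to compound 3 (0.09 log units; within the scatter). Compound 4 `COc1ccc(-c2nn(-c3ccccc3)cc2-c2nc3cc(C)ccc3[nH]2)cc1` has not yet been measured in this assay. Within the data shown here, its difference from compound 3 is methyl in place of trifluoromethyl on an aromatic carbon, which is the same change as the one made from compound 2 to compound 1, placed on the same position of the fused ring; this change occurs twice among the compounds here. Since the earlier step of a 1.6-fold lower number from compound 2 to compound 1 (0.22 log units; within the scatter) was small, the step from compound 3 to compound 4 is expected to be a 1.6-fold lower number from compound 3 to compound 4 (0.21 log units; within the scatter), an expectation that rests on that one earlier step and on nothing else. For compound 4 the estimated number in this assay is 3000 nM, with a likely range from 1500 nM to 6000 nM.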

Compound 4, half-maximal inhibitory concentration: 5070 nM
Compound 4: the middle estimate sits 1.7-fold (0.23 log units) below what was measured; measured number inside the range.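

In this assay, putting methyl in place of trifluoromethyl on the core that carries the methoxy group gives a 1.1-fold higher number from compound 3 to compound 4 (0.02 log units; within the scatter), and this step does not differ measurably from its earlier counterpart: the same change on two cores in this assay, a 1.6-fold lower number (0.22 log units; within the scatter) from compound 2 to compound 1 and a 1.1-fold higher number (0.02 log units; within the scatter) from compound 3 to compound 4, 1.7-fold (0.24 log units) apart, within the scatter of two such steps. Putting methoxy in place of hydrogen on the methyl-bearing core gives a 1.4-fold higher number from compound 1 to compound 4 (0.15 log units; within the scatter), and the same holds for this change: the same change on two cores in this assay, a 1.2-fold lower number (0.09 log units; within the scatter) from compound 2 to compound 3 and a 1.4-fold higher number (0.15 log units; within the scatter) from compound 1 to compound 4, 1.7-fold (0.24 log units) apart, within the scatter of two such steps. Together these comparisons show that each change carried from one core to the other without a detectable difference, but every step is itself within the scatter, so they do not show that either change has a real effect that transfers, nor do two cores establish a rule for the series.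

Going by these compounds, it remains open whether a different group on the same aromatic carbon, such as an amine or a carboxylic acid, would move the number beyond the scatter. The same question stands for a longer chain, such as ethoxy or butoxy, in place of the methoxy group.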